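A few compounds are considered here, and "the series" means these few. Any claim that something is new, unique, unknown or untested is made for them only; others in the source may bear on it.

Working notes on the series.

Three compounds carry the shared core of compound 1 `CC1=C(/C=C/C(=O)/C=C/c2ccccc2)C(C)(C)CCC1O`, which in a functional assay on LNCaP cells (Homo sapiens) for cytotoxicity, read by MTT assay, with a stated time of 72 h (a higher number here means a weaker inhibitor, a lower number a stronger inhibitor), gives 5800 nM. Compound 2 `CC1=C(/C=C/C(=O)/C=C/c2ccccc2C(F)(F)F)C(C)(C)CCC1O` gives 2900 nM in this assay, and compound 3 `CC1=C(/C=C/C(=O)/C=C/c2cc(C(F)(F)F)ccc2C(F)(F)F)C(C)(C)CCC1O` gives 3200 nM. On these numbers compound 2 has the smallest value of the three, but the steps that reach it and leave it, a 2.0-fold lower number from compound 1 to compound 2 (0.30 log units; within the scatter) and a 1.1-fold higher number from compound 2 to compound 3 (0.04 log units; within the scatter), are both within the scatter, so the three compounds are not separated by this assay.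

The next compound, compound 4 `CC1=C(/C=C/C(=O)/C=C/c2c(F)cccc2C(F)(F)F)C(C)(C)CCC1O`, differs from compound 2 by fluoro in place of hydrogen on an aromatic carbon. The two measured steps are the only ones that bear on it: each puts a fluorine-bearing group on the same aromatic carbon set, and neither moves this assay beyond the scatter. A change of this kind is therefore expected to leave this assay essentially where compound 2 left it, with no step beyond the scatter, as expressed by no change at the digits printed from compound 2 to compound 4 (within the scatter). Compound 4 is estimated at 2900 nM, in the range 1200 nM to 7000 nM.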

Compound 4, half-maximal inhibitory concentration: 4900 nM
For compound 4 the middle estimate is 1.7-fold (0.23 log units) below the measured one; the measured number falls inside the stated range.
By their numbers in this assay, from the lowest: compounds 2, 3, 4 and 1 (each within the scatter of the next).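

Fluoro on an aromatic carbon, ortho to a large group and meta to a trifluoromethyl group, gives a 1.7-fold higher number from compound 2 to compound 4 (0.23 log units; within the scatter) in this assay and so does not separate the two compounds. The aromatic ring has now carried a single fluorine atom as well as trifluoromethyl groups, and none of the three steps on it lies beyond the scatter. Nothing measured here bears on why this step has its size.

On these data alone, whether an amine or a carboxylic acid at this same aromatic carbon would give a step beyond the scatter in this assay remains open. Also open, as far as these compounds go, is whether any change to the shared core outside the aromatic ring would separate these compounds.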